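A Methyl Added to the Saturated Ring of Compound 1

The source may hold more compounds than are shown below. What is called first, only, known or untested is meant among the compounds shown, and "the series" means these compounds.

In an ADME assay on microsomes from liver (Rattus norvegicus) for metabolic stability (on this read-out higher numbers stand for a longer-lived compound and lower numbers for a shorter-lived compound), compound 1 (`CN1C(=O)COc2cc(Nc3cc4c(cn3)ncn4CC3CC3)ccc21`) gives 0.317 h and compound 3 (`CN1C(=O)COc2ccc(Nc3cc4c(cn3)ncn4CC3CC3)cc21`) gives 0.417 h. Within the data shown here, these two numbers lie within the scatter of each other, at the low end of the three measured so far. Compound 2 (`O=C1COc2cc(Nc3cc4c(cn3)ncn4CC3CC3)ccc2N1`) gives 0.983 h. Compound 4 (`CC1Oc2cc(Nc3cc4c(cn3)ncn4CC3CC3)ccc2N(C)C1=O`) alters compound 1 in one place: methyl in place of hydrogen on a saturated ring carbon. Among the measured compounds shown here, the only measured step, a 3.1-fold higher number from compound 1 to compound 2 (0.49 log units; beyond the scatter), replaces methyl with hydrogen on an amide-type nitrogen, a different place and the reverse kind of swap, so it offers little guidance here. For the measured compounds named here, no measured step covers this ring carbon, so no change beyond the scatter is expected, and the estimated step is a 1.1-fold lower number from compound 1 to compound 4 (0.02 log units; within the scatter). Compound 4 is expected at 0.3 h, within an estimated range of 0.15 h to 0.6 h.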

Compound 4, half-life: 0.917 h
The estimate for compound 4 lay 3.1-fold (0.49 log units) below the measured number, and the stated range ends below it.
By their numbers in this assay, from the lowest: compounds 1 and 3 (each within the scatter of the next); then compounds 4 and 2 (each within the scatter of the next).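

In this assay the methyl on this saturated ring carbon, next to the ring oxygen, gives a 2.9-fold higher number from compound 1 to compound 4 (0.46 log units; beyond the scatter) and so shows that this carbon is a sensitive place, where adding a single small group changes the result. Alongside a 3.1-fold higher number from compound 1 to compound 2 (0.49 log units; beyond the scatter) on the amide-type nitrogen, it marks a second place in the same ring where one change raises the number for compound 1. Nothing measured here explains the rise. The compounds shown leave open whether an ethyl or a hydroxyl group on this carbon would behave like methyl. They also leave open whether this methyl and the hydrogen on the ring nitrogen would add up in one compound.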